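The source may hold more compounds than are shown below. What is called first, only, known or untested is meant among the compounds shown, and "the series" means these compounds.

In an ADME assay on the whole organism with Oryza sativa as the target, tested at 0.1 uM (a higher number here means a weaker effect of the compound at the concentration tested, a lower number a stronger effect), compound 2 `C[C@H](NC(=O)Nc1cccc(Cl)c1)c1ccccc1` gives 103%. Its only measured companion, compound 1 `COc1cccc(NC(=O)N[C@@H](C)c2ccccc2)c1`, gives 101% in this assay. Compound 2 therefore stands alongside compound 1: the step of a number 2 percentage points higher from compound 1 to compound 2 (within the scatter) is within the scatter, so the two numbers cannot be told apart.

Compound 3 `C[C@H](NC(=O)Nc1cc(Cl)cc(Cl)c1)c1ccccc1` has not yet been measured in this assay. It differs from compound 2 in one place: chloro in place of hydrogen on an aromatic carbon. The change puts a second chloro group on the same ring, meta to the chloro group already present.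

Going by the values given here, only one measured step exists, a number 2 percentage points higher from compound 1 to compound 2 (within the scatter), and it swaps one group for another rather than adding a chloro group in place of hydrogen, so it bears on compound 3 only loosely. That step was within the scatter, and nothing measured here points to a change beyond it. The expected step is a number 1 percentage points lower from compound 2 to compound 3 (within the scatter). Compound 3 is estimated at 102% in this assay, within a range from 90% to 112%.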

Compound 3, a percentage reported as activity, at one concentration (the size of the read-out at that concentration, not a potency): 99%
Compound 3: the middle estimate sits 3 percentage points above what was measured, within the range that was stated.
By their numbers in this assay, from the lowest: compounds 3, 1 and 2 (each within the scatter of the next).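

Putting a chloro group in place of hydrogen on this aromatic carbon, meta to a chloro group, gives a number 4 percentage points lower from compound 2 to compound 3 (within the scatter) in this assay and so cannot be told apart from no change. Going by these compounds alone, the earlier step only swapped methoxy for chloro, whereas this one adds a group to the ring, and a second chloro group at this position leaves the read-out where the scatter cannot separate it from that of the single chloro group. No measured evidence bears on this result, so it offers no explanation for it.

Still open, from the compounds shown here alone, is whether an amine, a carboxylic acid or a longer chain at this position would move the number beyond the scatter. Equally open, going by these compounds, is whether a change elsewhere on the shared core would do so.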